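Extending the Alkoxy Chain: From Compound 2 to Compound 3

The source may hold more compounds than are shown below. What is called first, only, known or untested is meant among the compounds shown, and "the series" means these compounds.

Compound 1 `COc1ccc(N2C[C@@H](C)N[C@@H](C)C2)cc1NS(=O)(=O)c1ccc(-c2ccccn2)s1` gives 1.1
Compound 2 `CCOc1ccc(N2C[C@@H](C)N[C@@H](C)C2)cc1NS(=O)(=O)c1ccc(-c2ccccn2)s1` gives 0.8

Both compounds were tested in a functional assay for agonist activity at growth hormone secretagogue receptor type 1 (Homo sapiens), read by FLIPR; a higher number here means a larger maximal response, a lower number a smaller maximal response. Within the data shown here, compound 2 stands lowest of the two numbers measured; its only neighbour is compound 1, which sits higher by a step beyond the usual scatter. That single measured step, a number 0.30 lower from compound 1 to compound 2 (beyond the scatter), arose from methyl in place of hydrogen on a saturated chain carbon bound to an oxygen on an aromatic ring, that is, from methoxy to ethoxy.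

Compound 3 `CC(C)Oc1ccc(N2C[C@@H](C)N[C@@H](C)C2)cc1NS(=O)(=O)c1ccc(-c2ccccn2)s1` carries this same kind of growth one bond further out, ethoxy to isopropoxy: methyl in place of hydrogen on a saturated chain carbon bound to an oxygen on an aromatic ring and a saturated chain carbon. Among the measured compounds shown here, the one step that bears on it is the modest drop from compound 1 to compound 2, so a further fall of similar or somewhat smaller size is expected rather than a rise or a flat result. The estimated step a number 0.20 lower from compound 2 to compound 3 (beyond the scatter) is therefore downward. Compound 3 is expected to give about 0.6, with a plausible range from 0.35 to 0.85, because only a number 0.30 lower from compound 1 to compound 2 (beyond the scatter) supports the direction.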

Compound 3, intrinsic activity: the largest response reached, as a fraction of the reference agonist's: 1.1
The estimate for compound 3 lay 0.50 below the measured number; the whole stated range lies below it.
By their numbers in this assay, from the lowest: compound 2; then compounds 1 and 3 (each within the scatter of the next).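

In this assay, the same kind of change, methyl in place of hydrogen, now runs the other way: the earlier a number 0.30 lower from compound 1 to compound 2 (beyond the scatter) is not repeated, and this further methyl gives a number 0.30 higher from compound 2 to compound 3 (beyond the scatter) on the carbon bound to the oxygen on the aromatic ring. Comparing the two ends of the series, isopropyl in place of methyl on that oxygen gives no change at the digits printed from compound 1 to compound 3 (within the scatter), so the maximal response does not follow a steady trend with the growing group, and compound 2 alone stands apart from the other two compounds. Nothing available here explains this turn in direction.

From the compounds shown here alone, with only methoxy, ethoxy and isopropoxy in hand, it remains open whether the lower value of compound 2 belongs to straight chains in general or to ethoxy alone, which a longer straight chain such as propyl on the same oxygen would help to settle. Going by these compounds, it is equally open whether branching can be carried further without losing the response, as a tert-butyl or cyclopropyl group on that oxygen would test.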